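The source may hold more compounds than are shown below. What is called first, only, known or untested is meant among the compounds shown, and "the series" means these compounds.

Measured so far in a functional assay on SK-MEL-28 cells (Homo sapiens) for antiproliferative activity, read by MTT assay, with a stated time of 72 h; on this read-out lower numbers stand for stronger inhibition and higher numbers for weaker inhibition:
- Compound 1 (`O=C1Nc2c(F)cccc2/C1=C1/Nc2ccccc2C1=O`): > 100000 nM as a limit
- Compound 2 (`O=C1Nc2c(Cl)cccc2/C1=C1/Nc2ccccc2C1=O`): > 100000 nM as a limit
- Compound 3 (`O=C1Nc2ccccc2/C1=C1/Cc2ccccc2C1=O`): > 100000 nM as a limit

Compound 3 stands at > 100000 nM which is a limit of the assay and not a number. Among the measured compounds shown here, the whole set rests at the limit of > 100000 nM in this assay, at which 3 of the 3 values shown sit, so no compound here can be ranked against another.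

Compound 4 (`O=C1Nc2ccc(Br)cc2/C1=C1/Cc2ccccc2C1=O`) has not yet been measured. Its difference from compound 3 is bromo in place of hydrogen on an aromatic carbon and the new group sits on the six-membered aromatic ring of carbon only, meta to a fused ring and para to a fused ring.

For the measured compounds named here, the one measured step that comes near this change is a step that the two limits leave unreadable from compound 1 to compound 2 and it has no readable size. It also swaps one halogen for another on the core of compound 1 and does not put a halogen in place of hydrogen, so it gives no size to carry over. The expectation in this assay is therefore no clear change, with at most a modest shift toward stronger inhibition. The estimated move is an at least 1.4-fold lower number from compound 3 to compound 4 (0.15 log units; that floor lies within the scatter) and it remains uncertain. For compound 4 the expected value is 70000 nM with an estimated range from 15000 nM to 150000 nM and a further limit is the likeliest report.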

Compound 4, half-maximal inhibitory concentration: > 100000 nM
Compound 4 was reported as a limit; the forecaster's own chance of this, stated with the estimate: 60%; at least 1.4-fold (0.15 log units) between middle value and limit.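

In this assay, compound 3 and compound 4 are both reported as limits, so no step between them can be read: the limit of > 100000 nM in this assay, at which 4 of the 4 values shown sit.

The compounds shown leave open how any of them would rank against the others, and whether bromo in place of hydrogen on an aromatic carbon changes the read-out at all.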